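Bromo loss and a longer ether chain

This account rests on a few compounds, and the source may have more. Where it says the series, first, only, none or still open, it means among the compounds named here.

compound 1 `Cc1cc(=O)c2c(O)cc(OCc3ccccc3)c([C@H]3CCN(C)C[C@H]3O)c2o1` gives 24% here
compound 2 `Cc1cc(=O)c2c(O)cc(OCc3ccccc3Br)c([C@H]3CCN(C)C[C@H]3O)c2o1` gives 3% here

In a functional assay on HL-60 cells (Homo sapiens) for inhibition, read by MTT assay, with a stated time of 48 h, tested at 10 uM (on this read-out lower numbers stand for less inhibition of growth and higher numbers for more inhibition of growth at the one concentration tested), compound 2 sits at 3% as the lower of the two numbers. Compound 3 `Cc1cc(=O)c2c(O)cc(OC/C=C/c3ccccc3)c([C@H]3CCN(C)C[C@H]3O)c2o1` is not yet measured, and the change to it is 2-phenylethenyl in place of 2-bromophenyl on a saturated chain carbon bound to an oxygen on an aromatic ring with 2-phenylethenyl in place of 2-bromophenyl. For the measured compounds named here, one measured step bears on this: a number 21 percentage points lower from compound 1 to compound 2 (beyond the scatter) for bromo in place of hydrogen on an aromatic carbon. Compound 3 carries no bromo but also differs from compound 1, so only part of that gap is expected to return in this assay as a rise. A modest upward step a number 11 percentage points higher from compound 2 to compound 3 (beyond the scatter) is expected. For compound 3 the estimate is 14% as the expected value, within an expected range from 2% to 32% in this series.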

Compound 3, percent growth inhibition at one concentration: 21%
Compound 3: middle estimate off by 7 percentage points, on the low side; low and high end bracket the measured number.
By their numbers in this assay, from the lowest: compound 2; then compounds 3 and 1 (each within the scatter of the next).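

In this assay the ether position carries 3-phenylprop-2-en-1-yl without leaving the level of compound 1, the step being a number 3 percentage points lower from compound 1 to compound 3 (within the scatter) here. The other step reads a number 18 percentage points higher from compound 2 to compound 3 (beyond the scatter) and so, of the three compounds, only the 2-bromobenzyl ether stands apart. No measurement at hand accounts for this.

Open, on these data alone, is whether a saturated 3-phenylpropyl chain or an amine on the aromatic ring would hold this level. Also open, as far as these compounds go, is whether bromo would lower the number on the 3-phenylprop-2-en-1-yl group too.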